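The source may report more compounds than this note shows. Statements on the series, on what has been measured and on what is new or still open speak of the compounds shown alone.

Compound 1, `CCc1ccc(-c2cc(Cl)cc(C(=O)Nc3nn[nH]n3)n2)cc1`, gives 49% in a functional assay on the whole organism with Rattus norvegicus as the target, at a dose of 1 mg/kg by the oral route; a lower number here means a weaker effect, a higher number a stronger effect of the compound at the dose given. Within the data shown here, compound 2, `Nc1ccc(-c2cc(Cl)cc(C(=O)Nc3nn[nH]n3)n2)cc1`, gives 100% in this assay, the higher of the two numbers measured so far; the single measured step, a number 51 percentage points higher from compound 1 to compound 2 (beyond the scatter), sets compound 2 apart from compound 1 by more than the scatter. The inhibition shown by compound 2 is the largest a percentage of this kind can reach, so any further step from it can only be downward or within the scatter.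

Compound 3, `CCCOc1cc(C(=O)Nc2nn[nH]n2)nc(-c2ccc(N)cc2)c1`, differs from compound 2 at one place: propoxy in place of chloro on an aromatic carbon. Among the measured compounds shown here, no measured step bears on this change; the only step recorded, from compound 1 to compound 2, concerns the 4-aminophenyl group and leaves the chloro untouched, so it gives no guide to exchanging chloro for propoxy. With nothing to go on, the expectation is that compound 3 stays near compound 2, allowing a modest loss, expressed as an expected step of a number 15 percentage points lower from compound 2 to compound 3 (beyond the scatter). Compound 3 is therefore estimated to give 85%, within a range from 55% to 100%.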

Compound 3, a percentage reported as inhibition, in the whole organism at one dose (the size of the read-out at that dose, not a potency): 64%
Compound 3: middle estimate off by 21 percentage points, on the high side; the range from low to high includes it.
By their numbers in this assay, from the lowest: compound 1; then compound 3; then compound 2.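

In this assay, the chloro opposite the ring nitrogen had been common to compound 1 and compound 2, so the earlier step said nothing about this position; propoxy in place of chloro now gives a number 36 percentage points lower from compound 2 to compound 3 (beyond the scatter), which shows that this position affects the read-out at the dose given. The change is not all-or-nothing, however: with propoxy, 4 heavy atoms including an oxygen, replacing a single chlorine, compound 3 still gives 64% in this assay, so this position accepts a larger group while retaining a substantial part of the effect. Nothing available here explains why this exchange lowers the number.

The single replacement leaves open whether the drop follows from the oxygen or from the length of the chain, which a methoxy group, a butoxy chain, a plain propyl chain or an amine at this position could help to separate. From the compounds shown here alone, it also remains open whether the step would have the same size with the 4-ethylphenyl group of compound 1 in place of the 4-aminophenyl group.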